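The source may report more compounds than this note shows. Statements on the series, on what has been measured and on what is new or still open speak of the compounds shown alone.

Compound 1 `O=C(Nc1ccc(Oc2ccccc2)cc1)Oc1ccccc1F`: in an assay on H4 cells for inhibition of Fatty-acid amide hydrolase 1 (Homo sapiens) (a lower number here means a stronger inhibitor, a higher number a weaker inhibitor), compound 1 gives 1300 nM.
Compound 2 `CCCCOc1ccc(NC(=O)Oc2ccccc2F)cc1`: in this assay compound 2 gives 340 nM.

Of these two numbers compound 2 has the lower one; its nearest neighbour is compound 1, and the step of a 3.8-fold lower number from compound 1 to compound 2 (0.58 log units; beyond the scatter) lies beyond the scatter. Compound 3 `CCCCCCCOc1ccc(NC(=O)Oc2ccccc2F)cc1` has not yet been measured in this assay. It differs from compound 2 by propyl in place of hydrogen on a saturated chain carbon, four bonds along the chain from an oxygen on an aromatic ring, so the chain on the aromatic oxygen grows from butyl to heptyl. Among the measured compounds shown here, only one measured step bears on this region of the molecule, a 3.8-fold lower number from compound 1 to compound 2 (0.58 log units; beyond the scatter), which replaced a ring on that oxygen with a chain. For the measured compounds named here, it says nothing directly about lengthening a chain that is already there, and no measured pair does. The change is therefore expected to be small, within or only just beyond the scatter: for compound 3 the expected step is a 1.7-fold lower number from compound 2 to compound 3 (0.23 log units; within the scatter). For compound 3 the estimate in this assay is 200 nM, with a range from 60 nM to 700 nM.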

Compound 3, half-maximal inhibitory concentration: 28 nM
Estimate against measurement, compound 3: 7.1-fold (0.85 log units) above; the whole stated range lies above it.
By their numbers in this assay, from the lowest: compound 3; then compound 2; then compound 1.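

Lengthening the chain on the aromatic oxygen from butyl to heptyl has a strong effect in this assay, giving a 12-fold lower number from compound 2 to compound 3 (1.08 log units; beyond the scatter) and ranking as a large step, whereas the change from phenyl to butyl was modest. The earlier pair showed only a ring giving way to a chain, while this result shows that the length of the chain itself matters greatly at this position, and replacing phenyl with heptyl gives a 46-fold lower number from compound 1 to compound 3 (1.67 log units; beyond the scatter) overall. Nothing available here accounts for this difference.

On these data alone, whether the number keeps falling with a longer chain such as decyl, or rises again, remains open. So do the way pentyl and hexyl fit between butyl and heptyl, and the effect of an amine or a carboxylic acid at the far end of the chain.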